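The source may hold more compounds than are shown below. What is called first, only, known or untested is meant among the compounds shown, and "the series" means these compounds.

Three anilides built on the same core have been measured in a functional assay on HL-60 cells (Homo sapiens) for cytotoxicity, read by luminescence and CellTiter-Glo, with a stated time of 3 days; a higher number here means a weaker inhibitor, a lower number a stronger inhibitor. Compound 1 `Cc1ccc(C(=O)Nc2ccc(C#N)cc2)c(O)c1` gives 2420 nM in this assay. Compound 2 `N#Cc1ccc(NC(=O)c2cc(Cc3ccccc3)ccc2O)cc1` gives 1740 nM, and compound 3 `N#Cc1ccc(NC(=O)c2ccc3ccccc3c2O)cc1` gives 3410 nM. Compound 1 sits between the other two numbers: its nearest neighbour is compound 2 and the furthest is compound 3, yet both gaps fall within the usual scatter of repeated measurements, so the three compounds cannot be told apart on these data.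

The compound not yet measured is compound 4 `N#Cc1ccc(NC(=O)c2ccc(Cl)cc2O)cc1`. It differs from compound 1 in a single place: chloro in place of methyl on an aromatic carbon. The group that leaves and the group that enters are each a single heavy atom without ring, donor or acceptor, and the rest of the molecule is untouched.

Among the compounds with values here, nothing among the three measured compounds traces this particular exchange, so there is no directly comparable step to lean on. On that basis the change from compound 1 to compound 4 is expected to produce no step beyond the scatter, estimated as a 1.1-fold lower number from compound 1 to compound 4 (0.04 log units; within the scatter). Compound 4 is therefore expected to give about 2200 nM in this assay, with a likely range from 1000 nM to 5000 nM.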

Compound 4, half-maximal inhibitory concentration: 1300 nM
Compound 4: middle estimate off by 1.7-fold (0.23 log units), on the high side; the measured number falls inside the stated range.
By their numbers in this assay, from the lowest: compounds 4, 2, 1 and 3 (each within the scatter of the next, the first and the last beyond it).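

Within the data shown here, the exchange of chloro in place of methyl gives the first traceable step at this position, on an aromatic carbon meta to a hydroxy group and para to a large group: in this assay, it amounts to a 1.9-fold lower number from compound 1 to compound 4 (0.27 log units; within the scatter). This step stays within the scatter, so compound 4 cannot be told apart from compound 1, and at this position the two single-atom groups are not separated on these data. No accompanying measurement bears on this result or offers any account of it.

What the compounds shown leave open is how far this tolerance extends, as a single exchange between two groups without ring, donor or acceptor says little about groups of another kind on the same aromatic carbon. Whether an amine, a methoxy group or a carboxylic acid placed there would stay within the scatter of compound 1 or produce a step beyond it in this assay remains unanswered, as does whether chloro would read the same on a different version of the shared core.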